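Trifluoromethyl in Place of Chloro: Estimating Compound 4

A few compounds are considered here, and "the series" means these few. Any claim that something is new, unique, unknown or untested is made for them only; others in the source may bear on it.

Compound 1 `CC(c1ccc(-c2ccccc2)c(F)c1)c1nnc2n1N=C(c1ccc(C(F)(F)F)cc1)CS2` gives 6100 nM in a functional assay on HCT-116 cells (Homo sapiens) for inhibition, read by sulforhodamine B assay, with a stated time of 72 h; on this read-out higher numbers stand for weaker inhibition and lower numbers for stronger inhibition.
Compound 2 `CC(c1ccc(-c2ccccc2)c(F)c1)c1nnc2n1N=C(c1ccc(Cl)cc1)CS2` gives 7800 nM in this assay.
Compound 3 `COc1ccc2cc(C(C)c3nnc4n3N=C(c3ccc(Cl)cc3)CS4)ccc2c1` gives 8800 nM in this assay.

Compound 4 `COc1ccc2cc(C(C)c3nnc4n3N=C(c3ccc(C(F)(F)F)cc3)CS4)ccc2c1` has not yet been measured. Compound 3 and compound 2 carry different cores, and the difference between the two cores is not broken down here. The change from compound 3 to compound 4 is trifluoromethyl in place of chloro on an aromatic carbon. The same change, (trifluoromethyl in place of chloro on an aromatic carbon), links two measured compounds and gave a 1.3-fold lower number from compound 2 to compound 1 (0.11 log units; within the scatter); it appears in two pairs among the compounds shown, at the same place in both. Because a 1.3-fold lower number from compound 2 to compound 1 (0.11 log units; within the scatter) lies within the scatter, the expected step is a 1.3-fold lower number from compound 3 to compound 4 (0.10 log units; within the scatter). Compound 4 is therefore estimated at 7000 nM in this assay, with a likely range from 3500 nM to 14000 nM.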

Compound 4, half-maximal inhibitory concentration: 10800 nM
The estimate for compound 4 lay 1.5-fold (0.19 log units) below the measured number, and the stated range covers the measured number.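

In this assay, going by these compounds alone, trifluoromethyl in place of chloro gives a 1.2-fold higher number from compound 3 to compound 4 (0.09 log units; within the scatter), so on this core, too, the swap produces no step that can be told apart from repeat-measurement noise. This does not show that either group is better, nor that the result would hold on a third core or in a different assay. Across the two cores shown, the swap carries over without a detectable difference between its steps: the same change on two cores in this assay, a 1.3-fold lower number (0.11 log units; within the scatter) from compound 2 to compound 1 and a 1.2-fold higher number (0.09 log units; within the scatter) from compound 3 to compound 4, 1.6-fold (0.20 log units) apart, within the scatter of two such steps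

The compounds shown leave open whether an amine or a carboxylic acid at this place on the ring would shift the number beyond the scatter. They also leave open whether any change at this place would carry from one core to the other once its step is large enough to read clearly.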